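Working notes: exchanging the aryl substituent on the fused ring

The source may hold more compounds than are shown below. What is called first, only, known or untested is meant among the compounds shown, and "the series" means these compounds.

Measured so far:
compound 1 `Nc1ncc(-c2cnn(C3CCNCC3)c2)cc1-c1nc2ccc(Nc3ccc(F)cc3)cc2o1` gives 3700 nM in an assay on isolated protein for inhibition of G protein-coupled receptor kinase 5 (Homo sapiens), read by TR-FRET, with stated times of 10 min and 1 h; on this read-out higher numbers stand for weaker inhibition and lower numbers for stronger inhibition
compound 2 `Nc1ncc(-c2cnn(C3CCNCC3)c2)cc1-c1nc2ccc(-c3ccc4[nH]ncc4c3)cc2o1` gives 1140 nM in this assay

Going by the values given here, compound 2 stands lowest of the two numbers; the single known step is a 3.2-fold lower number from compound 1 to compound 2 (0.51 log units; beyond the scatter). Compound 3 `Nc1ncc(-c2cnn(C3CCNCC3)c2)cc1-c1nc2ccc(Oc3cc(Cl)ccn3)cc2o1` differs from compound 2 by (4-chloropyridin-2-yl)oxy in place of 1H-indazol-5-yl on an aromatic carbon. Among the compounds with values here, only that one step bears on this change, and it does so loosely: the group removed in going to compound 3 is the one whose arrival gave the lower number. A return toward the region of compound 1 is therefore expected, with a 2.6-fold higher number from compound 2 to compound 3 (0.42 log units; beyond the scatter) in this assay. Compound 3 is estimated at 3000 nM, with a range of 1000 nM to 9000 nM.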

Compound 3, half-maximal inhibitory concentration: 5700 nM
For compound 3 the middle estimate is 1.9-fold (0.28 log units) below the measured one, and the stated range covers the measured number.
By their numbers in this assay, from the lowest: compound 2; then compounds 1 and 3 (each within the scatter of the next).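

(4-Chloropyridin-2-yl)oxy in place of 1H-indazol-5-yl on this aromatic carbon gives a 5.0-fold higher number from compound 2 to compound 3 (0.70 log units; beyond the scatter) and so does not keep the lower number of compound 2. The step of a 1.5-fold higher number from compound 1 to compound 3 (0.19 log units; within the scatter) leaves the (4-fluorophenyl)amino and (4-chloropyridin-2-yl)oxy groups indistinguishable here, and of the three groups only 1H-indazol-5-yl stands apart. No supporting data explain this difference.

Open, on these data alone, is whether the hydrogen-bond donor of 1H-indazol-5-yl matters, which a 1-methylindazol-5-yl group would test. Also open, as far as these compounds go, is how a directly attached phenyl or a morpholine would read at this position.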